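This account rests on a few compounds, and the source may have more. Where it says the series, first, only, none or still open, it means among the compounds named here.

Three compounds share one core and differ only in the aryl group attached to a carbon with a double bond to nitrogen. Compound 1 `COc1ccc(OC)c(/C=N/NC(=O)Nc2ccc(Oc3ccnc(-c4nncn4CCN(C)C)c3)c(F)c2)c1` gives 2070 nM in a functional assay on HT-29 cells (Homo sapiens) for cytotoxicity, read by MTT assay, with a stated time of 72 h; on this read-out lower numbers stand for stronger inhibition and higher numbers for weaker inhibition. Compound 2 `CN(C)CCn1cnnc1-c1cc(Oc2ccc(NC(=O)N/N=C/c3ccc(O)c(O)c3)cc2F)ccn1` gives 1890 nM in this assay, and compound 3 `CN(C)CCn1cnnc1-c1cc(Oc2ccc(NC(=O)N/N=C/c3cc(Br)c(O)c(Br)c3)cc2F)ccn1` gives 2670 nM. The number for compound 2 sits at the lower end of the three, yet a 1.1-fold lower number from compound 1 to compound 2 (0.04 log units; within the scatter) and a 1.4-fold higher number from compound 2 to compound 3 (0.15 log units; within the scatter) both fall within the scatter, as does a 1.3-fold higher number from compound 1 to compound 3 (0.11 log units; within the scatter), so none of the three can be ranked against the others.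

Compound 4 `Cc1cc(/C=N/NC(=O)Nc2ccc(Oc3ccnc(-c4nncn4CCN(C)C)c3)c(F)c2)cc(C)c1O` has not yet been measured in this assay. It differs from compound 2 in a single place: 4-hydroxy-3,5-dimethylphenyl in place of 3,4-dihydroxyphenyl on a carbon with a double bond to nitrogen. Every measured step here is of the same kind, an exchange of one aryl group for another at this same carbon, and none of them moved the number beyond the scatter. On that basis compound 4 is expected to behave like its neighbours, with a 1.2-fold higher number from compound 2 to compound 4 (0.07 log units; within the scatter) amounting to no real change. The estimate for compound 4 in this assay is therefore 2200 nM, with a range from 1100 nM to 4400 nM.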

Compound 4, half-maximal inhibitory concentration: 1220 nM
The estimate for compound 4 lay 1.8-fold (0.26 log units) above the measured number; the range from low to high includes it.
By their numbers in this assay, from the lowest: compounds 4, 2, 1 and 3 (each within the scatter of the next, the first and the last beyond it).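

In this assay, the exchange at this carbon now gives a step that leaves the scatter, a 2.2-fold lower number from compound 3 to compound 4 (0.34 log units; beyond the scatter), so the aryl group here can change the number, if only slightly. The other two new steps, a 1.5-fold lower number from compound 2 to compound 4 (0.19 log units; within the scatter) and a 1.7-fold lower number from compound 1 to compound 4 (0.23 log units; within the scatter), stay within the scatter, so the 4-hydroxy-3,5-dimethylphenyl group cannot be told apart from the 3,4-dihydroxyphenyl or 2,5-dimethoxyphenyl groups, and the single clear difference is the one between the 3,5-dibromo-4-hydroxyphenyl group and the 4-hydroxy-3,5-dimethylphenyl group. No measurement is available that could explain this difference.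

From the compounds shown here alone, all four groups at this carbon are phenyl rings carrying only hydroxy, methoxy, bromo or methyl groups, so the effect of a ring bearing an amine or a carboxylic acid, or of a longer chain in place of the methyl groups, remains open. Going by these compounds, it also remains open whether any group at this carbon can move the number further than this one modest step, or whether the position tolerates almost any such exchange.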